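Carbamate series: cyclopentyl to 3-fluorophenyl on the nitrogen

The source may report more compounds than this note shows. Statements on the series, on what has been measured and on what is new or still open speak of the compounds shown alone.

For the measured compounds named here, two carbamates have numbers so far. Compound 1 `Cc1ccc(C(C)C)c(OC(=O)Nc2ccc([N+](=O)[O-])cc2)c1` gives 32.8% in a toxicity assay on the whole organism (H4IIE cells) for cytotoxicity, with Rattus norvegicus as the target, read by MTT assay, with a stated time of 24 h, tested at 5 uM; on this read-out lower numbers stand for a stronger effect and higher numbers for a weaker effect at the one concentration tested. Compound 2 `Cc1ccc(C(C)C)cc1OC(=O)NC1CCCC1` gives 38.9% in this assay; its number is the higher of the two, but it sits within the scatter of compound 1, so the two compounds cannot be told apart on this read-out. Going by the values given here, no step between measured compounds is available, since compounds 1 and 2 differ in more than one place.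

Compound 3 `Cc1ccc(C(C)C)cc1OC(=O)Nc1cccc(F)c1` is the next candidate for this assay. It differs from compound 2 by 3-fluorophenyl in place of cyclopentyl on an amide-type nitrogen. Among the compounds with values here, the only related point of comparison is compound 1, which also carries a substituted phenyl on the amide-type nitrogen and gives 32.8%. The step from compound 2 to compound 3 is expected to be small, at most toward a lower number, a number 4.9 percentage points lower from compound 2 to compound 3 (within the scatter), and not clearly beyond the scatter. Compound 3 is accordingly estimated at 34%, in the range 20% to 50%.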

Compound 3, a percentage reported as activity, at one concentration (the size of the read-out at that concentration, not a potency): 37.2%
Compound 3: middle estimate off by 3.2 percentage points, on the low side; the measured number falls inside the stated range.
By their numbers in this assay, from the lowest: compounds 1, 3 and 2 (each within the scatter of the next).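

For the compounds shown here, the only readable step in this assay is a number 1.7 percentage points lower from compound 2 to compound 3 (within the scatter) and it comes with 3-fluorophenyl in place of cyclopentyl on the amide-type nitrogen. At this position, on this read-out, a fluorinated six-membered aromatic ring and a five-membered non-aromatic carbon ring therefore cannot be told apart, which the earlier pair, differing in more than one place, could not show. Nothing on hand bears on why the two groups read alike.

Still open, as far as these compounds go, is whether any group on this nitrogen moves the number beyond the scatter, for instance a longer alkyl chain, a chain ending in an amine or a carboxylic acid. Also open, from the compounds shown here alone, is how unsubstituted phenyl or a smaller group such as methyl would read against cyclopentyl and 3-fluorophenyl.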